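This account rests on a few compounds, and the source may have more. Where it says the series, first, only, none or still open, it means among the compounds named here.

In a physicochemical assay for solubility (a lower number here means a less soluble compound, a higher number a more soluble compound), compound 2 `C[C@H](Oc1ccc(S(C)(=O)=O)cc1C(=O)N1Cc2ccc(N3CCN(C)CC3)cc2C1)C(F)(F)F` gives 490 ug/mL, level within the scatter with compound 3 `C[C@H](Oc1ccc(S(C)(=O)=O)cc1C(=O)N1Cc2cccc(C#N)c2C1)C(F)(F)F` at 259 ug/mL, while compound 1 `C[C@H](Oc1ccc(S(C)(=O)=O)cc1C(=O)N1Cc2ccc(C(F)(F)F)cc2C1)C(F)(F)F` stays far lower at 1 ug/mL. Compound 2 therefore belongs to the upper pair of this small set.

The next structure is compound 4 `C[C@H](Oc1ccc(S(C)(=O)=O)cc1C(=O)N1Cc2ccc(C3CCCCO3)cc2C1)C(F)(F)F`, not yet measured: oxan-2-yl in place of 4-methylpiperazin-1-yl on an aromatic carbon. In words, oxan-2-yl stands in place of 4-methylpiperazin-1-yl on an aromatic carbon, meta to a fused ring and para to a fused ring.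

Going by the values given here, one measured step bears on this change, a 490-fold higher number from compound 1 to compound 2 (2.69 log units; beyond the scatter), a large step with 4-methylpiperazin-1-yl in place of trifluoromethyl on an aromatic carbon. Compound 4 gives up that same 4-methylpiperazin-1-yl, so a large fall in this assay is expected, though probably not the whole way back to compound 1. Among the compounds with values here, no measured compound carries oxan-2-yl, and no single-place step links compound 3 to the others, so the size of the fall is poorly fixed and the range has to stay wide.

The expected step, as estimated here, is a 33-fold lower number from compound 2 to compound 4 (1.51 log units; beyond the scatter). Compound 4 is estimated at 15 ug/mL, with an expected range of 2 ug/mL to 100 ug/mL.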

Compound 4, solubility: < 1 ug/mL
Compound 4 ended at the assay's limit (the forecaster's own chance of this, stated with the estimate: 10%); at least 15-fold (1.17 log units) between middle value and limit.
By their numbers in this assay, from the lowest: compound 1; then compounds 3 and 2 (each within the scatter of the next).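

In this assay compound 4 gives < 1 ug/mL, which is a limit of the assay and not a number: the limit of < 1 ug/mL in this assay, at which 1 of the 4 values shown sits.

Oxan-2-yl in place of 4-methylpiperazin-1-yl on this aromatic carbon, para to a fused ring, gives an at least 490-fold lower number from compound 2 to compound 4 (2.69 log units; beyond the scatter), so a six-membered non-aromatic ring at this place is not enough to keep the high number of compound 2. Oxan-2-yl in place of trifluoromethyl on this aromatic carbon gives a number no higher from compound 1 to compound 4 (the limit leaves the size open), a step that cannot be read, but trifluoromethyl and oxan-2-yl both sit at the low end of the assay's numbers, and of the three groups shown at this place only 4-methylpiperazin-1-yl gives a high number.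

Still open, going by these compounds, is which part of 4-methylpiperazin-1-yl goes with the high number: morpholin-4-yl, piperidin-1-yl or an open-chain amine such as dimethylamino at this same carbon would separate the ring nitrogens from the ring itself. Going by these compounds alone, compound 3 carries a nitrile at another place on the core and has no single-place step to the others, so how that place relates to this one also remains unresolved.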